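From Tetrazolyl to Carboxyphenyl on the Shared Core

The compounds below may be only part of what the source reports. "The series", "measured", "known", "first", "only" and "open" are said of these compounds alone.

Three compounds share one core and differ only in the group carried on an aromatic carbon of a six-membered aromatic ring of carbon only, para to a large group. Compound 1 `CCC(C)(C)Cc1c[nH]c(CCc2ccc(-c3cnccn3)cc2)n1` gives 107 nM in a functional assay on HEK293 cells for agonist activity at Bombesin receptor subtype-3 (Mus musculus), read by luminescence and calcium flux, with a stated time of 10 min; on this read-out higher numbers stand for an effect only at larger amounts of compound and lower numbers for an effect already at smaller amounts; compound 2 `CCC(C)(C)Cc1c[nH]c(CCc2ccc(-n3ncnn3)cc2)n1` gives 99 nM there, and compound 3 `CCC(C)(C)Cc1c[nH]c(CCc2ccc(-c3cnsc3)cc2)n1` gives 119 nM. Compound 2 sits among these numbers within the scatter of both others: the step of a 1.1-fold lower number from compound 1 to compound 2 (0.03 log units; within the scatter) and the step of a 1.2-fold higher number from compound 2 to compound 3 (0.08 log units; within the scatter) are within the scatter, as is a 1.1-fold higher number from compound 1 to compound 3 (0.05 log units; within the scatter). Compound 4 `CCC(C)(C)Cc1c[nH]c(CCc2ccc(-c3ccccc3C(=O)O)cc2)n1` takes the step (2-carboxyphenyl in place of 2H-tetrazol-2-yl on an aromatic carbon). Within the data shown here, the three measured steps bear on it only loosely, since each exchanges one five-membered ring with hetero atoms for another and none moved the number beyond the scatter; the group entering here is larger and carries a hydrogen-bond donor, which no measured step tested. The estimate rests on the flatness seen so far, widened for the new kind of group, so a step of a 1.5-fold higher number from compound 2 to compound 4 (0.18 log units; within the scatter) is expected. For compound 4 an expected value of 150 nM is estimated, within a range from 50 nM to 600 nM.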

Compound 4, half-maximal effective concentration: 94 nM
The estimate for compound 4 lay 1.6-fold (0.20 log units) above the measured number; the range from low to high includes it.
By their numbers in this assay, from the lowest: compounds 4, 2, 1 and 3 (each within the scatter of the next).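

The 2-carboxyphenyl group differs from the earlier groups in kind, with 9 heavy atoms and a hydrogen-bond donor, yet on this aromatic carbon para to a large group in this assay its steps are a 1.1-fold lower number from compound 2 to compound 4 (0.02 log units; within the scatter) and a 1.1-fold lower number from compound 1 to compound 4 (0.06 log units; within the scatter) and also a 1.3-fold lower number from compound 3 to compound 4 (0.10 log units; within the scatter), all within the scatter. Among these compounds, the flatness seen among compounds 1, 2 and 3 therefore extends to compound 4, so this position now shows no separation even for a change larger than any the earlier steps covered. Nothing measured here accounts for why these groups read alike.

The compounds shown leave open whether a carboxylic acid set directly on this aromatic carbon, an amine or a longer chain would also stay within the scatter. They also leave open whether this flatness holds on any other read-out.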